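Ether series: step from compound 2 to compound 3

The source may report more compounds than this note shows. Statements on the series, on what has been measured and on what is new or still open speak of the compounds shown alone.

Working notes on two measured ethers and one analogue awaiting assay. Compound 1 `O=c1cc(O)c2ccc(OCc3cccc(F)c3)cc2o1` gives 2090 nM in an assay on isolated protein (strain Sprague-Dawley) for inhibition of Amine oxidase [flavin-containing] B (Rattus norvegicus), read by spectrophotometry, with a stated time of 5 min; on this read-out higher numbers stand for weaker inhibition and lower numbers for stronger inhibition. Compound 2 `CC(C)Oc1cc(=O)oc2cc(OCc3cccc(Cl)c3)ccc12` gives 24500 nM in this assay and holds the higher of the two numbers, with compound 1 the lower; the gap between them is beyond the usual scatter. Compound 3 `CNC(=O)COc1cc(=O)oc2cc(OCc3cccc(Cl)c3)ccc12` differs from compound 2 by (methylcarbamoyl)methyl in place of isopropyl on an oxygen on an aromatic ring. Within the data shown here, no step of this kind has been measured, so the expected step of a 1.6-fold lower number from compound 2 to compound 3 (0.21 log units; within the scatter) is a modest one toward a lower number, scarcely beyond the scatter. Compound 3 is therefore estimated at 15000 nM, within 4000 nM to 60000 nM.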

Compound 3, half-maximal inhibitory concentration: 33.9 nM
Compound 3: the middle estimate sits 440-fold (2.65 log units) above what was measured, outside the stated range (below it).
By their numbers in this assay, from the lowest: compound 3; then compound 1; then compound 2.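

In this assay the change from isopropyl to (methylcarbamoyl)methyl on this oxygen gives a 720-fold lower number from compound 2 to compound 3 (2.86 log units; beyond the scatter) and so shows that the read-out is highly sensitive to the group at this position. Compound 1 and compound 2 differ in more than one place and could not show this. Nothing measured here explains the size of the step.

Going by these compounds, it remains open which part of the entering group carries the step, which an N,N-dimethylacetamide or a plain methoxy ether on the same oxygen would help separate. A carboxylic acid or a longer amide chain there is also untested in the compounds shown.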